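The source may hold more compounds than are shown below. What is called first, only, known or untested is meant among the compounds shown, and "the series" means these compounds.

Measured in a physicochemical assay for solubility, read by HPLC; a higher number here means a more soluble compound, a lower number a less soluble compound:
compound 1 `O=C(c1ccccc1F)N1CCN(c2nc(=O)c3cc(C(F)(F)F)cc([N+](=O)[O-])c3s2)CC1` gives 3.1 ug/mL;
compound 2 `Cc1ccc(C(=O)N2CCN(c3nc(=O)c4cc(C(F)(F)F)cc([N+](=O)[O-])c4s3)CC2)cc1` gives 6.7 ug/mL;
compound 3 `O=C(c1ccccc1Cl)N1CCN(c2nc(=O)c3cc(C(F)(F)F)cc([N+](=O)[O-])c3s2)CC1` gives 8.18 ug/mL.

Compound 3 gives the highest number of the three, though compound 2 sits within the scatter of it; only compound 1 lies clearly lower. Compound 4 `CCCCC(=O)N1CCN(c2nc(=O)c3cc(C(F)(F)F)cc([N+](=O)[O-])c3s2)CC1` differs from compound 3 by butyl in place of 2-chlorophenyl on a carbonyl carbon. Among the compounds with values here, the steps so far, a 2.2-fold higher number from compound 1 to compound 2 (0.33 log units; beyond the scatter), a 2.6-fold higher number from compound 1 to compound 3 (0.42 log units; beyond the scatter) and a 1.2-fold higher number from compound 2 to compound 3 (0.09 log units; within the scatter), all alter a substituted phenyl on the carbonyl carbon and none exchanges the ring for a chain, so they bear only loosely on this step. With all three numbers in a narrow band, no step beyond the scatter is expected for a 1.2-fold higher number from compound 3 to compound 4 (0.09 log units; within the scatter). Compound 4 is estimated at 10 ug/mL, with a range of 4 ug/mL to 25 ug/mL.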

Compound 4, solubility: 42.5 ug/mL
For compound 4 the middle estimate is 4.3-fold (0.63 log units) below the measured one, and the stated range ends below it.
By their numbers in this assay, from the lowest: compound 1; then compounds 2 and 3 (each within the scatter of the next); then compound 4.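

Butyl in place of each substituted phenyl on the carbonyl carbon gives a higher number in this assay (a 5.2-fold higher number from compound 3 to compound 4 (0.72 log units; beyond the scatter); a 6.3-fold higher number from compound 2 to compound 4 (0.80 log units; beyond the scatter); a 14-fold higher number from compound 1 to compound 4 (1.14 log units; beyond the scatter)). At this position, exchanging a ring for a chain therefore separates compound 4 from all three phenyl compounds, whereas changes among the phenyls gave smaller steps. No measurement shown accounts for this result.

Going by these compounds, whether the ring's removal or the butyl chain itself matters stays open; cyclohexyl or a longer chain on the same carbonyl carbon would help separate the two. On these data alone, how an amine at the chain end would read also remains open.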